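Trifluoromethyl for amino on the pendant phenyl of compound 2

The source may report more compounds than this note shows. Statements on the series, on what has been measured and on what is new or still open speak of the compounds shown alone.

In a functional assay on NCI-H1993 cells (Homo sapiens) for inhibition, read by CCK-8 assay, with a stated time of 72 h (on this read-out lower numbers stand for stronger inhibition and higher numbers for weaker inhibition), compound 1 `OCCn1cc(-c2cnc3ncn(Cc4ccc5ncccc5c4)c3n2)cn1` gives 2330 nM and compound 2 `Nc1ccc(-c2cnc3ncn(Cc4ccc5ncccc5c4)c3n2)cc1` gives 4950 nM, the higher of the two numbers shown; the only measured step is a 2.1-fold higher number from compound 1 to compound 2 (0.33 log units; beyond the scatter). Compound 3 `FC(F)(F)c1ccc(-c2cnc3ncn(Cc4ccc5ncccc5c4)c3n2)cc1` carries trifluoromethyl in place of amino on an aromatic carbon. Within the data shown here, no measured step swaps a substituent on that six-membered ring, so the step from compound 1 to compound 2 bears only loosely, showing that the group at this position moves this assay modestly. A modest shift toward higher numbers is expected for compound 3, a 1.2-fold higher number from compound 2 to compound 3 (0.08 log units; within the scatter), with the estimate 6000 nM and a range of 2000 nM to 18000 nM.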

Compound 3, half-maximal inhibitory concentration: > 10000 nM
Compound 3 ended at the assay's limit; the forecaster's own chance of this, stated with the estimate: 10%; middle value at least 1.6-fold (0.22 log units) from the limit.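

The step from amino to trifluoromethyl on the phenyl is an at least 2.0-fold higher number from compound 2 to compound 3 (0.30 log units; that floor lies within the scatter) and, read as a floor, does not by itself separate the two compounds. The step from the 1-(2-hydroxyethyl)-1H-pyrazol-4-yl group is clearer, an at least 4.2-fold higher number from compound 1 to compound 3 (0.63 log units; beyond the scatter) and so the group at this place moves the number further than the earlier pair showed. Compound 3 stands at a limit, not at a number: the limit of > 10000 nM in this assay, at which 1 of the 3 values shown sits.

Going by these compounds, how far compound 3 lies past that limit remains open. Also open, on these data alone, is whether a nitrile, a methoxy group or a carboxylic acid on the same phenyl would read closer to compound 2.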